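Shortening the ester chain in a thienyl pyrimidinone

The compounds below may be only part of what the source reports. "The series", "measured", "known", "first", "only" and "open" are said of these compounds alone.

Of the compounds shown here, three have been measured in an assay on membranes from CHO cells for displacement of a labelled ligand from adenosine receptor A1 (Homo sapiens), read by scintillation counting, with a stated time of 60 min, tested at 1 uM; on this read-out higher numbers stand for more inhibition at the one concentration tested (going by the name of the read-out) and lower numbers for less inhibition. Compound 1 `CCCOC(=O)C1=C(C)NC(=S)NC1c1ccco1` gives 1%, and compound 2 `CC1=C(C(=O)OCC(C)C)C(c2ccco2)NC(=S)N1` gives 7%. Between them the step of a number 6 percentage points lower from compound 2 to compound 1 (within the scatter) is hydrogen in place of methyl on a saturated chain carbon bound to two saturated chain carbons. Compound 3 `CCC(CC)OC(=O)C1=C(C)NC(=O)NC1c1cccs1` gives 13%; the difference between the core of compound 3 and the core of compound 2 is not broken down here. Compound 4 `CCC(C)OC(=O)C1=C(C)NC(=O)NC1c1cccs1` is not yet measured; it arises from compound 3 by hydrogen in place of methyl on a saturated chain carbon, two bonds along the chain from an oxygen next to a carbonyl group. This is the same kind of change as from compound 2 to compound 1, but its place differs: in compound 1 the carbon is bound to two saturated chain carbons, whereas in compound 4 it is two bonds along the chain from an oxygen next to a carbonyl group. Because a number 6 percentage points lower from compound 2 to compound 1 (within the scatter) lay within the scatter, the step of a number 3 percentage points lower from compound 3 to compound 4 (within the scatter) is expected to be small as well. Compound 4 is therefore estimated to give 10% in this assay, most likely between 0% and 25%.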

Compound 4, a percentage reported as inhibition, at one concentration (the size of the read-out at that concentration, not a potency): 5%
Estimate against measurement, compound 4: 5 percentage points above; the measured number falls inside the stated range.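

In this assay the change of methyl to hydrogen gives a number 8 percentage points lower from compound 3 to compound 4 (within the scatter) and so stays close to the earlier step on the other core: the same change on two cores in this assay, a number 6 percentage points lower (within the scatter) from compound 2 to compound 1 and a number 8 percentage points lower (within the scatter) from compound 3 to compound 4, 2 percentage points apart, within the scatter of two such steps. On these two cores, the change therefore carries over as a small step of similar size. Within the data shown here, neither step lies beyond the scatter, so this shows only that no clear change appears on either core, not that removing the methyl lowers inhibition or that other cores would behave alike.

The compounds shown leave open how a much longer chain or a benzyl ester would read on either core. They also leave open what a carboxylic acid or an amide in place of the ester would do.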